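This account rests on a few compounds, and the source may have more. Where it says the series, first, only, none or still open, it means among the compounds named here.

Working notes on an in vivo ADME assay on the whole organism (plasma, strain Sprague-Dawley) for pharmacokinetics, with Rattus norvegicus as the target, read by LC-MS; on this read-out higher numbers stand for fast clearance and lower numbers for slow clearance. Compound 2 `CC(C)(C)c1cc(NC(=O)Nc2ccc(NC(=O)c3ccc(OC4CCN(C5CC5)CC4)cn3)cc2)no1` gives 12 mL/min/kg, which lies within the scatter of compound 1 `CC(C)(C)c1cc(NC(=O)Nc2ccc(NC(=O)c3ccc(OC4CCN(C(C)(C)C)CC4)cn3)cc2)no1` at 15 mL/min/kg and compound 3 `CC1(C)CC(Oc2ccc(C(=O)Nc3ccc(NC(=O)Nc4cc(C(C)(C)C)on4)cc3)nc2)CC(C)(C)N1` at 11 mL/min/kg. Compound 4 `CC(C)N1CCC(Oc2ccc(C(=O)Nc3ccc(NC(=O)Nc4cc(C(C)(C)C)on4)cc3)nc2)CC1` differs from compound 2 in one place, with isopropyl in place of cyclopropyl on an amine nitrogen in a ring. The closest measured change on that nitrogen is a 1.3-fold lower number from compound 1 to compound 2 (0.10 log units; within the scatter), swapping tert-butyl for cyclopropyl. The wider replacements, a 1.4-fold lower number from compound 1 to compound 3 (0.13 log units; within the scatter) and a 1.1-fold lower number from compound 2 to compound 3 (0.04 log units; within the scatter), are also small. All three lie within the scatter, so no step beyond it is expected in this assay, and no direction is favoured. The estimated change is a 1.1-fold higher number from compound 2 to compound 4 (0.03 log units; within the scatter). The expected value for compound 4 is 13 mL/min/kg, with an estimated range of 7 mL/min/kg to 24 mL/min/kg.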

Compound 4, clearance: 16 mL/min/kg
Estimate against measurement, compound 4: 1.2-fold (0.09 log units) below, within the range that was stated.
By their numbers in this assay, from the lowest: compounds 3, 2, 1 and 4 (each within the scatter of the next).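

In this assay, isopropyl in place of cyclopropyl on the amine nitrogen gives a 1.3-fold higher number from compound 2 to compound 4 (0.12 log units; within the scatter), so losing the three-membered ring with no change in heavy atoms stays within the scatter at this position. The other two new steps, a 1.5-fold higher number from compound 3 to compound 4 (0.16 log units; within the scatter) and a 1.1-fold higher number from compound 1 to compound 4 (0.03 log units; within the scatter), also stay within the scatter, so all four piperidin-4-yl groups in the series remain indistinguishable on this read-out. No evidence on the origin of these values is available.

Still open, on these data alone, is whether a longer chain or a carboxylic acid on this nitrogen would give a step beyond the scatter in this assay.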